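The compounds below may be only part of what the source reports. "The series", "measured", "known", "first", "only" and "open" are said of these compounds alone.

- Compound 1 `COc1cc(-c2cccc3nc(-c4ccc(F)cc4)oc23)cc(OC)c1OC`: > 25000 nM (a limit)
- Compound 2 `COc1cc(-c2cccc3nc(-c4cccc(Br)c4)oc23)cc(OC)c1OC`: 6800 nM
- Compound 3 `COc1cc(-c2cccc3nc(-c4ccc(Br)cc4)oc23)cc(OC)c1OC`: > 25000 nM (a limit)

These compounds were tested in a functional assay on U-251 cells (Homo sapiens) for antiproliferative activity, read by MTT assay, with a stated time of 48 h; on this read-out lower numbers stand for stronger inhibition and higher numbers for weaker inhibition. Compound 3 stands at the limit of > 25000 nM in this assay, at which 2 of the 3 values shown sit, so it has a limit rather than a number. Compound 4 `COc1cc(-c2nc3cccc(-c4cc(OC)c(OC)c(OC)c4)c3o2)ccc1O` carries 4-hydroxy-3-methoxyphenyl in place of 4-bromophenyl (4-hydroxy-3-methoxyphenyl in place of 4-bromophenyl on an aromatic carbon). Two measured steps can be sized: an at least 3.6-fold lower number from compound 1 to compound 2 (0.56 log units; beyond the scatter) and an at least 3.6-fold higher number from compound 2 to compound 3 (0.56 log units; beyond the scatter). Both involve the 3-bromophenyl group. A third, a step that the two limits leave unreadable from compound 1 to compound 3, gives no usable size. The 4-hydroxy-3-methoxyphenyl resembles the 3-bromophenyl in part and the 4-bromophenyl in part. A modest fall in the number is therefore expected, an at least 1.7-fold lower number from compound 3 to compound 4 (0.25 log units; that floor lies within the scatter), although a result at the limit remains possible. Compound 4 is expected at 14000 nM, with an estimated range of 5000 nM to 35000 nM.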

Compound 4, half-maximal inhibitory concentration: 10300 nM
For compound 4 the middle estimate is 1.4-fold (0.13 log units) above the measured one; low and high end bracket the measured number.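

At this aromatic carbon, a substituted phenyl without bromine can also give a measurable number in this assay: 4-hydroxy-3-methoxyphenyl gives an at least 2.4-fold lower number from compound 3 to compound 4 (0.38 log units; beyond the scatter) and an at least 2.4-fold lower number from compound 1 to compound 4 (0.38 log units; beyond the scatter). Against 3-bromophenyl, the same group gives a 1.5-fold higher number from compound 2 to compound 4 (0.18 log units; within the scatter), so compound 2 and compound 4 cannot be told apart here. The first two steps are floors rather than full sizes because compound 1 and compound 3 each stop at a limit: the limit of > 25000 nM in this assay, at which 2 of the 4 values shown sit.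

The compounds shown leave open which of the hydroxy and methoxy groups matters. They also leave open how an amine or a carboxylic acid on this phenyl ring would behave.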